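Halogen swap in a thiazole hydrazone series: cytotoxicity outlook

A few compounds are considered here, and "the series" means these few. Any claim that something is new, unique, unknown or untested is made for them only; others in the source may bear on it.

Compound 1, `C/C(=N\Nc1nc(-c2ccc(Cl)cc2)cs1)c1sc(C)nc1C`: in a toxicity assay on THP-1 cells (Homo sapiens) for cytotoxicity, read by MTT assay (a higher number here means a weaker inhibitor of growth, a lower number a stronger inhibitor of growth), compound 1 gives > 100 ug/mL, which is a limit of the assay and not a number.
Compound 2, `C/C(=N\Nc1nc(-c2ccc(Br)cc2)cs1)c1sc(C)nc1C`: in this assay compound 2 gives > 100 ug/mL, again a limit of the assay.
Compound 3, `C/C(=N\Nc1nc(-c2ccc(Cl)cc2)cs1)c1sc(-c2ccccc2)nc1C`: in this assay compound 3 gives > 100 ug/mL, also a limit of the assay.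

All three measured values sit at the same place, (the limit of > 100 ug/mL in this assay, at which 3 of the 3 values shown sit), so no ordering among them can be read. The change from compound 1 to compound 2 is bromo in place of chloro on an aromatic carbon, and the step it made, a step that the two limits leave unreadable from compound 1 to compound 2, cannot be sized, since both ends are limits. The cores of compound 1 and compound 3 differ by phenyl in place of methyl on an aromatic carbon, and that step too, a step that the two limits leave unreadable from compound 1 to compound 3, stays hidden behind the two limits.

Compound 4, `C/C(=N\Nc1nc(-c2ccc(Br)cc2)cs1)c1sc(-c2ccccc2)nc1C`, has not yet been measured. It differs from compound 3 by bromo in place of chloro on an aromatic carbon, the same change as from compound 1 to compound 2, made on the core of compound 3 rather than that of compound 1. Nothing in the measured set distinguishes the halogen pair, and nothing distinguishes the two cores, so the expectation for compound 4 rests on compound 3 and its value > 100 ug/mL together with the unreadable step that the two limits leave unreadable from compound 1 to compound 2. Compound 4 is therefore expected to give 150 ug/mL, most likely again reported only as a limit, with an expected step that the limit leaves unreadable from compound 3 to compound 4 between the lower end 80 ug/mL and the upper end 400 ug/mL.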

Compound 4, concentration for 50% growth inhibition: 48.9 ug/mL
For compound 4 the middle estimate is 3.1-fold (0.49 log units) above the measured one, outside the stated range (below it).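

Going by these compounds, on the core of compound 3, bromo in place of chloro gave an at least 2.0-fold lower number from compound 3 to compound 4 (0.31 log units; beyond the scatter) in this assay, so the change from 4-chlorophenyl to 4-bromophenyl has a readable effect on this core, though its full size stays open. Among these compounds, a readable value appears only where bromo and phenyl stand together: with bromo held in place, phenyl in place of methyl gave an at least 2.0-fold lower number from compound 2 to compound 4 (0.31 log units; beyond the scatter), and neither compound 2 nor compound 3, each carrying only one of the two groups, shows a readable value. This does not show that the halogen step carries over from one core to another, since the same change on the core of compound 1 and the other steps that join two limits cannot be read: the limit of > 100 ug/mL in this assay, at which 3 of the 4 values shown sit.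

On these data alone, it remains open whether the core of compound 1 responds to bromo at all, or whether the step belongs to the core of compound 3 alone. The compounds shown also leave open what an amine or a carboxylic acid in place of the bromo would do, and what a longer chain in place of the phenyl would do, on either core.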